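The compounds below may be only part of what the source reports. "The series", "measured", "known", "first", "only" and "open" are said of these compounds alone.

Measured so far:
compound 1 `O=C(NCCNc1nccc(-c2c(-c3cccc(F)c3)nc3sccn23)n1)c1ccc(C(F)(F)F)cc1`: 9260 nM
compound 2 `O=S(=O)(NCCCNc1nccc(-c2c(-c3cccc(F)c3)nc3sccn23)n1)c1ccccc1`: 6850 nM
compound 3 `O=C(NCCNc1nccc(-c2c(-c3cccc(F)c3)nc3sccn23)n1)c1ccccc1`: 17000 nM

All three numbers come from a functional assay on SK-MEL-28 cells (Homo sapiens) for cytotoxicity, read by MTT assay; a higher number here means a weaker inhibitor, a lower number a stronger inhibitor. Compound 2 stands at the low end of the three: the gap to compound 1 lies within the scatter, while the step of a 2.5-fold higher number from compound 2 to compound 3 (0.39 log units; beyond the scatter) is a modest one beyond it. Compound 4 `Cc1ccc(S(=O)(=O)NCCNc2nccc(-c3c(-c4cccc(F)c4)nc4sccn34)n2)cc1` differs from compound 2 by ((4-methylphenyl)sulfonyl)amino in place of ((phenylsulfonyl)amino)methyl on a saturated chain carbon, two bonds along the chain from a nitrogen on an aromatic ring. For the measured compounds named here, no measured step repeats this change exactly. The step of a 2.5-fold higher number from compound 2 to compound 3 (0.39 log units; beyond the scatter) alters the chain and the linking group together, and the step of a 1.8-fold higher number from compound 1 to compound 3 (0.26 log units; within the scatter) shows that changing a substituent on the outer aromatic ring stays within the scatter. For compound 4 a step of a 1.2-fold higher number from compound 2 to compound 4 (0.07 log units; within the scatter) is therefore expected, not beyond the scatter. The estimate for compound 4 is 8000 nM, expected to fall between 3500 nM and 18000 nM.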

Compound 4, half-maximal inhibitory concentration: > 20000 nM
Compound 4: no number, only a limit (the forecaster's own chance of this, stated with the estimate: 5%); middle value at least 2.5-fold (0.39 log units) away from the limit.
By their numbers in this assay, from the lowest: compounds 2, 1 and 3 (each within the scatter of the next, the first and the last beyond it). At a limit, above all of these: compound 4.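

Compound 4 gives a limit of the assay and not a number: the limit of > 20000 nM in this assay, at which 1 of the 4 values shown sits. In this assay, ((4-methylphenyl)sulfonyl)amino holds the same atoms as ((phenylsulfonyl)amino)methyl, yet the swap gives an at least 2.9-fold higher number from compound 2 to compound 4 (0.46 log units; beyond the scatter), so identical counts do not guarantee a matching read-out at this position. (4-Methylphenyl)sulfonyl in place of (4-(trifluoromethyl)phenyl)carbonyl gives an at least 2.1-fold higher number from compound 1 to compound 4 (0.33 log units; beyond the scatter), while in place of benzoyl it gives an at least 1.1-fold higher number from compound 3 to compound 4 (0.07 log units; that floor lies within the scatter), which sets no order.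

Going by these compounds, whether the methyl on the outer ring or the change in the chain carries the step stays open. So does the reading for a methoxy on that ring or a longer chain.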